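Working notes on compound 4 of the series

The source may report more compounds than this note shows. Statements on the series, on what has been measured and on what is new or still open speak of the compounds shown alone.

Compound 1 `CCCCCCCCc1ccc(OCC(=O)Cn2nnc(Cc3ccccc3)n2)cc1` gives 66 nM in an assay on microsomes from brain for inhibition of Fatty-acid amide hydrolase 1 (Rattus norvegicus), read by fluorescence and HPLC, with a stated time of 60 min; on this read-out higher numbers stand for weaker inhibition and lower numbers for stronger inhibition. Compound 2 `CC(Oc1ccc(Oc2ccc(F)cc2)cc1)C(=O)Cn1nnc(-c2ccccc2)n1` gives 24 nM in this assay, and compound 3 `CC(Oc1ccc(Oc2ccc(F)cc2)cc1)C(=O)Cn1nnc(-c2ccc(Cl)cc2)n1`, carrying chloro in place of hydrogen on an aromatic carbon, gives 42 nM; the step of a 1.8-fold higher number from compound 2 to compound 3 (0.24 log units; within the scatter) stays within the scatter. Compound 3 thus holds the second highest of the three numbers, within the scatter of both compound 1 and compound 2.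

Compound 4 `CC(Oc1ccc(-c2ccccc2)cc1)C(=O)Cn1nnc(-c2ccc(Cl)cc2)n1` differs from compound 3 by phenyl in place of 4-fluorophenoxy on an aromatic carbon. Among the measured compounds shown here, no measured step touches this part of the molecule: the only step, a 1.8-fold higher number from compound 2 to compound 3 (0.24 log units; within the scatter), concerns the chloro, and compounds 1 and 2, which differ in their tails, show numbers within the scatter of each other. In this assay no step beyond the scatter is therefore expected, a 1.2-fold higher number from compound 3 to compound 4 (0.08 log units; within the scatter). Compound 4 is estimated at 50 nM, range 15 nM to 170 nM.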

Compound 4, half-maximal inhibitory concentration: 25 nM
The estimate for compound 4 lay 2.0-fold (0.30 log units) above the measured number; the range from low to high includes it.
By their numbers in this assay, from the lowest: compounds 2, 4, 3 and 1 (each within the scatter of the next, the first and the last beyond it).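

In this assay, phenyl in place of 4-fluorophenoxy gives a 1.7-fold lower number from compound 3 to compound 4 (0.23 log units; within the scatter) as the first step read at this position. The change removes a hydrogen-bond acceptor, the oxygen and the fluorine, and two heavy atoms in all, yet the step stays within the scatter with the chloro present. No measurement at hand bears on the result. Going by these compounds, whether phenyl reads the same without the chloro stays open. Also open, on these data alone, is how an amine or a carboxylic acid on this aromatic carbon would read.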